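A Third Group on the Same Carbonyl Carbon

The source may report more compounds than this note shows. Statements on the series, on what has been measured and on what is new or still open speak of the compounds shown alone.

Compound 1 `CC(C)=CCCC1=CC[C@H](C(=O)NO)[C@@H](c2ccccc2)C1` gives 71700 nM
Compound 2 `CC(C)=CCCC1=CC[C@H](C(=O)O)[C@@H](c2ccccc2)C1` gives 53700 nM

Both numbers come from a functional assay on A549 cells (Homo sapiens) for antiproliferative activity (a lower number here means a stronger inhibitor, a higher number a weaker inhibitor), where compound 2 stands level with compound 1. Within the data shown here, the only measured step is a 1.3-fold lower number from compound 1 to compound 2 (0.13 log units; within the scatter). Compound 3 `CONC(=O)[C@H]1CC=C(CCC=C(C)C)C[C@@H]1c1ccccc1` carries a new change, methoxyamino in place of hydroxy on a carbonyl carbon. Among the measured compounds shown here, that measured step, which swapped hydroxyamino for hydroxy at this same carbon, is the only guide, so no shift beyond the scatter is expected in this assay. The estimated step is a 1.1-fold higher number from compound 2 to compound 3 (0.05 log units; within the scatter). Compound 3 is expected at 60000 nM, with an estimated range of 28000 nM to 120000 nM.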

Compound 3, half-maximal inhibitory concentration: 42200 nM
Estimate against measurement, compound 3: 1.4-fold (0.15 log units) above; the measured number falls inside the stated range.
By their numbers in this assay, from the lowest: compounds 3, 2 and 1 (each within the scatter of the next).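

Methoxyamino in place of hydroxy gives a 1.3-fold lower number from compound 2 to compound 3 (0.10 log units; within the scatter) in this assay, and methyl in place of hydrogen on the oxygen gives a 1.7-fold lower number from compound 1 to compound 3 (0.23 log units; within the scatter), so neither step lies beyond the scatter. This carbonyl carbon has now carried hydroxy, hydroxyamino and methoxyamino with all steps among them within the scatter, and the added methyl on the oxygen is a change that the earlier pair did not cover. No supporting measurement bears on this result. Still open, as far as these compounds go, is whether a plain amino group or a longer chain such as ethoxyamino on this carbon would give a step beyond the scatter.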